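This account rests on a few compounds, and the source may have more. Where it says the series, first, only, none or still open, it means among the compounds named here.

Three compounds have so far been measured in an assay on cells for inhibition of MAP kinase-interacting serine/threonine-protein kinase 1 (Homo sapiens), read by mobility shift assay, with stated times of 10 min and 60 min, in the presence of a further agent that is not named here; on this read-out lower numbers stand for stronger inhibition and higher numbers for weaker inhibition:

- compound 1 `NC(=O)c1ccc(-c2cccnc2)cc1OC1CCNCC1`: 1100 nM
- compound 2 `COc1cncc(-c2ccc(C(N)=O)cc2)c1`: 3000 nM
- compound 3 `Nc1ccc(-n2cnc(Cl)c2Cl)cc1`: 103000 nM

Compound 1 gives the lowest number of the three. The nearest to it is compound 2, whose number is higher by a margin beyond the usual scatter, and the furthest is compound 3, which lies far above both. No two of these measured compounds differ in only one place, so none of them shows directly what a single structural change does on this read-out.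

Compound 4 `NC(=O)c1ccc(-c2cccnc2)cc1OC1CCCCC1` has not been measured. It differs from compound 1 in one place: cyclohexyl in place of piperidin-4-yl on an oxygen on an aromatic ring. In words, this is cyclohexyl in place of piperidin-4-yl on an oxygen on an aromatic ring. Going by the values given here, nothing among the measured compounds shows the effect of exactly this exchange, so the expectation rests on compound 1 alone and on the counted difference.

The step from compound 1 to compound 4 is expected to be a moderate rise in the number, beyond the scatter, that is, a weakening: a 3.2-fold higher number from compound 1 to compound 4 (0.50 log units; beyond the scatter). Compound 4 is therefore estimated at 3500 nM, within a range from 1000 nM to 12000 nM.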

Compound 4, half-maximal inhibitory concentration: 1500 nM
For compound 4 the middle estimate is 2.3-fold (0.37 log units) above the measured one; low and high end bracket the measured number.
By their numbers in this assay, from the lowest: compounds 1, 4 and 2 (each within the scatter of the next, the first and the last beyond it); then compound 3.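

In this assay, the exchange at this position gives a 1.4-fold higher number from compound 1 to compound 4 (0.13 log units; within the scatter), and this is the first direct reading of a single structural change among the compounds shown. Replacing piperidin-4-yl with cyclohexyl removes the ring nitrogen, along with the hydrogen-bond donor and acceptor counted for that group, while the six-membered ring and its attachment through the oxygen remain, and the two numbers stay within the usual scatter of each other. For this one pair, then, the nitrogen of piperidin-4-yl is not needed to keep the number at the level of compound 1, although the result says nothing about other groups at this position or about the same exchange on another core.

It remains open how this position would respond to a group of a different kind, such as a carboxylic acid, a primary amine on a longer chain, or a small methyl ether in place of the six-membered ring, since both groups shown here are saturated six-membered rings. Nothing shown here explains why piperidin-4-yl and cyclohexyl give numbers so close together on this read-out.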